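The compounds below may be only part of what the source reports. "The series", "measured", "known", "first", "only" and "open" are said of these compounds alone.

Compound 1 `CC1(C)[C@@H]2CC[C@@]1(C)/C(=N/NC(=O)C(F)(F)F)C2`: > 250000 nM
Compound 2 `CCCC(=O)N/N=C1\C[C@H]2CC[C@]1(C)C2(C)C`: 854000 nM
Compound 3 `CC(=O)N/N=C1\C[C@H]2CC[C@]1(C)C2(C)C`: > 250000 nM

The three compounds share one core and differ only in the group on the carbonyl carbon. In an ADME assay on Vero cells (Chlorocebus sabaeus) for cytotoxicity, read by spectrophotometry, with a stated time of 4 days (a higher number here means that more compound is tolerated, a lower number that less compound is tolerated), compound 3 gives > 250000 nM, which is a limit of the assay and not a number. Compound 1 also stands at a limit in this assay, giving > 250000 nM. Compound 2 gives 854000 nM in this assay. Because of the limit of > 250000 nM in this assay, at which 2 of the 3 values shown sit, none of the three steps between the measured compounds can be sized: a step that the limit leaves unreadable from compound 1 to compound 2, a step that the two limits leave unreadable from compound 1 to compound 3 and a step that the limit leaves unreadable from compound 2 to compound 3 all remain unreadable. Compound 3 therefore stands at the limit, and nothing more exact can be said of where it sits.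

Compound 4 `CC1(C)[C@@H]2CC[C@@]1(C)/C(=N/NC(=O)c1ccco1)C2` differs from compound 3 by furan-2-yl in place of methyl on a carbonyl carbon. Among the compounds with values here, none of the measured steps brings in an aromatic ring, and the steps that do vary the group on the carbonyl carbon leave no readable size, so no direction for the step in this assay can be drawn from them; what the three measured compounds show is that each of them is tolerated up to high concentrations. Compound 4 is therefore expected to behave likewise, with an estimated step that the limit leaves unreadable from compound 3 to compound 4. The estimate for compound 4 in this assay is 300000 nM, with a range from 100000 nM to 1000000 nM.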

Compound 4, half-maximal cytotoxic concentration: 285000 nM
Compound 4: the middle estimate sits 1.1-fold (0.02 log units) above what was measured; the measured number falls inside the stated range.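

Within the data shown here, compound 4 gives the first step at this position that can be sized in this assay: a 3.0-fold lower number from compound 2 to compound 4 (0.48 log units; beyond the scatter). Among these compounds, with furan-2-yl standing where propyl stood, the change goes beyond the scatter, so the group at this position can move the tolerated concentration, which the earlier compounds could not show, although the step is modest and compound 4 still gives 285000 nM. The steps from compound 1 and from compound 3 to compound 4 cannot be read, because of a limit of the assay: the limit of > 250000 nM in this assay, at which 2 of the 4 values shown sit.

This single readable step exchanges a saturated chain for an aromatic ring, so the compounds shown do not tell whether the lower number follows from the furan-2-yl group itself or from the loss of propyl. Going by these compounds, it also remains open how a phenyl or thiophen-2-yl group, a longer chain such as hexyl, or an amine on this carbonyl carbon would stand in this assay.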